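Chloro in Place of Trifluoromethyl in Two Amide Cores

The source may report more compounds than this note shows. Statements on the series, on what has been measured and on what is new or still open speak of the compounds shown alone.

Compound 1 `N#Cc1ccc(NC(=O)c2cc(Cl)ccc2O)cc1` — 700 nM
Compound 2 `O=C(Nc1ccc(C(F)(F)F)cc1)c1ccc2cccnc2c1O` — 680 nM
Compound 3 `N#Cc1ccc(NC(=O)c2cc(C(F)(F)F)ccc2O)cc1` — 3120 nM

In a functional assay on HL-60 cells (Homo sapiens) for cytotoxicity, read by luminescence and CellTiter-Glo, with a stated time of 3 days (on this read-out higher numbers stand for weaker inhibition and lower numbers for stronger inhibition), compound 1 gives 700 nM and compound 3 gives 3120 nM. These two share a core and differ in one place: chloro in place of trifluoromethyl on an aromatic carbon. That change gives a 4.5-fold lower number from compound 3 to compound 1 (0.65 log units; beyond the scatter). Compound 2, built on a different core, gives 680 nM in this assay, a number within the scatter of compound 1; against compound 3 its number stands lower, beyond the scatter. How the core of compound 2 differs from the core of compound 3 is not broken down here.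

Compound 4 `O=C(Nc1ccc(Cl)cc1)c1ccc2cccnc2c1O` has not been measured. It differs from compound 2 in one place: chloro in place of trifluoromethyl on an aromatic carbon. Among the measured compounds shown here, this is the same kind of change as the one from compound 3 to compound 1, but the place around it is not the same: there the ring carbon was meta to a large group and para to a hydroxy group, here it is para to a large group, on the other ring of the molecule. For the measured compounds named here, the only guide is the single measured step, and it sits on a different ring and a different core. Because of a 4.5-fold lower number from compound 3 to compound 1 (0.65 log units; beyond the scatter) a lower number for compound 4 than for compound 2 is expected, though a smaller step, given that the surroundings differ. The expected step from compound 2 to compound 4 in this assay is a 1.7-fold lower number from compound 2 to compound 4 (0.23 log units; within the scatter). Compound 4 is thus estimated at 400 nM, with a likely range from 150 nM to 1400 nM.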

Compound 4, half-maximal inhibitory concentration: 630 nM
Estimate against measurement, compound 4: 1.6-fold (0.20 log units) below; the measured number falls inside the stated range.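

In this assay, putting chloro in place of trifluoromethyl gives a 1.1-fold lower number from compound 2 to compound 4 (0.03 log units; within the scatter), so on this core the change leaves the number effectively where it stood. The same swap therefore does not carry over from one core to the other with the same size, and the step seen on the first core would have been a poor guide to the second: the same change on two cores in this assay, a 4.5-fold lower number (0.65 log units; beyond the scatter) from compound 3 to compound 1 and a 1.1-fold lower number (0.03 log units; within the scatter) from compound 2 to compound 4, 4.1-fold (0.62 log units) apart, beyond the scatter of two such steps. This shows only that the size of the step depends on its surroundings in these two pairs; it does not show what in the surroundings matters, since the two pairs differ both in their core and in where the change sits, and two pairs cannot separate those two differences or say which step is the more typical.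

On these data alone, what a methyl group, a methoxy group or an amine would do in the place of chloro on either core remains open, and a comparison of such groups would show whether the first core responds strongly to every change there or only to this one. Also open, as far as these compounds go, is whether a third core would follow the large step, the small one, or neither.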